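Piperazine nitrogen alkyl variation on the shared core

The source may report more compounds than this note shows. Statements on the series, on what has been measured and on what is new or still open speak of the compounds shown alone.

Compound 1 `C#CCSc1nc(NCCC(C)C)c2ccncc2n1`, compound 2 `C#CCSc1nc(Nc2ccccc2)c2ccncc2n1` and compound 3 `C#CCSc1nc(N2CCN(C)CC2)c2ccncc2n1` share one core and differ only in the group on the aromatic carbon. In a functional assay on MGC-803 cells (Homo sapiens) for inhibition, read by MTT assay, with a stated time of 72 h (a higher number here means a weaker inhibitor, a lower number a stronger inhibitor), compound 2 gives 16200 nM. Compound 1 reaches only the limit of this assay, > 80000 nM. Compound 3 likewise stands at the limit, > 80000 nM. Compound 3 is thus one of the two compounds sitting at the limit of > 80000 nM in this assay, at which 2 of the 3 values shown sit, with no number beneath it. The measured steps read: an at least 4.9-fold lower number from compound 1 to compound 2 (0.69 log units; beyond the scatter); an at least 4.9-fold higher number from compound 2 to compound 3 (0.69 log units; beyond the scatter); a step that the two limits leave unreadable from compound 1 to compound 3.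

Compound 4 `C#CCSc1nc(N2CCN(CC)CC2)c2ccncc2n1` differs from compound 3 by methyl in place of hydrogen on a saturated chain carbon bound to an amine nitrogen in a ring. Within the data shown here, none of the measured steps touches this site; the two readable ones exchange the whole group on the aromatic carbon, and the third stays unreadable. So small a change at a saturated chain carbon gives no ground to expect a move beyond the scatter. Expected is a step that the limit leaves unreadable from compound 3 to compound 4, leaving compound 4 most likely again at the limit. Compound 4 is estimated at 100000 nM, range 40000 nM to 300000 nM.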

Compound 4, half-maximal inhibitory concentration: 70600 nM
Estimate against measurement, compound 4: 1.4-fold (0.15 log units) above; the measured number falls inside the stated range.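

Among these compounds, compound 4 gives the first number for a group of this kind on the shared core in this assay, 70600 nM, so this site can now be followed on a numeric scale. Compound 3 remains at a limit, > 80000 nM. Methyl to ethyl at this position gives an at least 1.1-fold lower number from compound 3 to compound 4 (0.05 log units; that floor lies within the scatter), which sets only a floor and leaves the true size of the step unread, and the comparison is bounded by a single limit: the limit of > 80000 nM in this assay, at which 2 of the 4 values shown sit.

From the compounds shown here alone, whether a longer chain such as propyl, or a benzyl or 2-hydroxyethyl group, at this position would move the number beyond the scatter stays open. Also open, going by these compounds, is whether a chloro or methoxy group on the phenyl of compound 2 would shift the value of compound 2, 16200 nM.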